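Ether substituent exchange: compound 2 to compound 4

A few compounds are considered here, and "the series" means these few. Any claim that something is new, unique, unknown or untested is made for them only; others in the source may bear on it.

Compound 2 `COc1ccccc1Oc1cncc(C2=CC3CNCC(C2)C3)c1` gives 56 nM in an in vitro assay on SH-SY5Y cells for displacement of a labelled ligand from Neuronal acetylcholine receptor; alpha3/beta4 (Homo sapiens); on this read-out lower numbers stand for stronger inhibition and higher numbers for weaker inhibition. Of the three numbers measured it stands second highest: compound 1 `C1=C(c2cncc(OCc3ccccc3)c2)CC2CNCC1C2` gives 44 nM, and compound 3 `CN1CC2C=C(c3ccc(F)nc3)CC(C2)C1` gives 1310 nM. Compound 4 `Clc1ccc(Oc2cncc(C3=CC4CNCC(C3)C4)c2)cc1` differs from compound 2 in one place: 4-chlorophenyl in place of 2-methoxyphenyl on an oxygen on an aromatic ring. For the measured compounds named here, the one measured step that bears on this change, a 1.3-fold higher number from compound 1 to compound 2 (0.10 log units; within the scatter), also exchanges the group on that oxygen and stays within the scatter. Going by the values given here, no measured compound carries a chlorine, so nothing shows its effect directly. The step expected here, a 1.1-fold higher number from compound 2 to compound 4 (0.03 log units; within the scatter), is therefore taken as none beyond the scatter. The estimate for compound 4 is 60 nM, with a range from 25 nM to 150 nM.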

Compound 4, inhibition constant: 40 nM
Compound 4: the middle estimate sits 1.5-fold (0.18 log units) above what was measured, and the stated range covers the measured number.
By their numbers in this assay, from the lowest: compounds 4, 1 and 2 (each within the scatter of the next); then compound 3.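

The oxygen on the aromatic ring takes three different groups in this assay with no step beyond the scatter: 4-chlorophenyl in place of 2-methoxyphenyl gives a 1.4-fold lower number from compound 2 to compound 4 (0.15 log units; within the scatter), and 4-chlorophenyl in place of benzyl gives a 1.1-fold lower number from compound 1 to compound 4 (0.04 log units; within the scatter). Compounds 1, 2 and 4 therefore read alike, and the chlorine adds no step beyond the scatter. Nothing shown explains why these groups read alike.

Going by these compounds, it remains open whether this holds without an aromatic ring on that oxygen, as with a methyl group or a longer alkyl chain. An amine or a carboxylic acid on the aromatic ring is also untested among the compounds shown.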